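Swapping the amino group of compound 3

The compounds below may be only part of what the source reports. "The series", "measured", "known", "first", "only" and "open" are said of these compounds alone.

Compound 1 `CCc1nc(NC(CC)CC)c(OC)nc1-c1ccc(Cl)cc1Cl` – 0.583 h
Compound 2 `CCc1nc(N(CC2CC2)CC2CC2)c(CC)nc1-c1ccc(Cl)cc1Cl` – 0.133 h
Compound 3 `CCCN(CCN(C)C)c1nc(CC)c(-c2ccc(Cl)cc2Cl)nc1CC` – 0.0833 h

In an in vitro ADME assay on microsomes (Homo sapiens) for metabolic stability (a higher number here means that the compound lasts longer, a lower number that the compound disappears faster), compound 3 stands at 0.0833 h, at the low end together with compound 2. Compound 1 gives 0.583 h, clearly above compound 3 at 0.0833 h.

Going on to compound 4 `CCc1nc(-c2ccc(Cl)cc2Cl)c(CC)nc1NC(CC)CC` changes one group: (pentan-3-yl)amino in place of (2-(dimethylamino)ethyl)(propyl)amino on an aromatic carbon. In words, (pentan-3-yl)amino comes in place of (2-(dimethylamino)ethyl)(propyl)amino, on the aromatic carbon para to a 2,4-dichlorophenyl group.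

For the measured compounds named here, only one measured step touches this place, a 1.6-fold lower number from compound 2 to compound 3 (0.20 log units; within the scatter). Going by the values given here, it exchanged a different pair of groups, so it shows only that one such swap stayed small. Compound 1 also carries (pentan-3-yl)amino and gives 0.583 h, but it differs from compound 4 elsewhere in the structure, which makes it a loose guide. Together these point to a moderate rise in this assay, short of the level of compound 1.

The expected change is a 3.6-fold higher number from compound 3 to compound 4 (0.56 log units; beyond the scatter). Compound 4 is estimated at 0.3 h, with an expected range from 0.1 h to 0.8 h.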

Compound 4, half-life: 0.283 h
Compound 4: middle estimate off by 1.1-fold (0.03 log units), on the high side, within the range that was stated.
By their numbers in this assay, from the lowest: compounds 3 and 2 (each within the scatter of the next); then compound 4; then compound 1.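

In this assay, for the compounds shown here, the (pentan-3-yl)amino group on this aromatic carbon brings a 3.4-fold higher number from compound 3 to compound 4 (0.53 log units; beyond the scatter) and also a 2.1-fold higher number from compound 2 to compound 4 (0.33 log units; beyond the scatter) so this swap moves the number beyond the scatter from either starting amino group, while the one earlier exchange at this carbon stayed within it. Ethyl in place of methoxy on an aromatic carbon gives a 2.1-fold lower number from compound 1 to compound 4 (0.31 log units; beyond the scatter) so a second place on the core also shifts the half-life, and the amino group alone does not set it. Nothing available explains why either change has this effect.

The swap from compound 3 to compound 4 removes the dimethylamino end, lowers the heavy-atom count and adds a hydrogen-bond donor all at once, so these compounds cannot separate the three. Going by these compounds, how a ring amine such as morpholine on this carbon would fare also stays open.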